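The source may hold more compounds than are shown below. What is called first, only, known or untested is meant among the compounds shown, and "the series" means these compounds.

Measured so far in an ADME assay on Huh-7 cells (Homo sapiens) for cytotoxicity, read by a luciferase reporter and WST assay, with a stated time of 3 days; a lower number here means that less compound is tolerated, a higher number that more compound is tolerated:
Compound 1 `Cc1ccccc1NC(=O)c1c(NO)cc(-c2ccccc2)oc1=O`: > 20000 nM
Compound 2 `CNC(=O)c1c(NO)cc(-c2ccc(F)cc2)oc1=O`: > 20000 nM

Compound 1 has no exact number here: it reads > 20000 nM, which is a limit. Compound 2 also gives only a limit. Among the measured compounds shown here, the record therefore shows (the limit of > 20000 nM in this assay, at which 2 of the 2 values shown sit), and no step between measured compounds can be read from it.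

Compound 3 `CC(C)NC(=O)c1c(NO)cc(-c2ccccc2)oc1=O` has not yet been measured. It keeps the core of compound 1 but carries isopropyl in place of 2-methylphenyl on an amide-type nitrogen.

No change beyond the usual scatter is expected in this assay, and another limit is the likeliest reading. That expectation rests on the limit of compound 1, > 20000 nM. The estimated step that the limit leaves unreadable from compound 1 to compound 3 is expected to stay within the scatter. For compound 3 the expected value is 25000 nM, with an estimated range of 12000 nM to 50000 nM.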

Compound 3, half-maximal cytotoxic concentration: > 20000 nM
Compound 3: only a limit was reported (the forecaster's own chance of this, stated with the estimate: 80%); the middle value does not contradict the limit.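

Among the compounds shown here, compound 1 and compound 3 each give only a limit in this assay, so no step between them can be read: the limit of > 20000 nM in this assay, at which 3 of the 3 values shown sit.

The compounds shown leave open at what concentration each would harm these cells, and whether isopropyl in place of 2-methylphenyl changes that concentration.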